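Replacing the 4-(dimethylamino)phenyl of compound 3

The compounds below may be only part of what the source reports. "The series", "measured", "known", "first", "only" and "open" are said of these compounds alone.

Results so far in a functional assay on HepG2 cells (Homo sapiens) for antiproliferative activity, read by MTT assay, with a stated time of 24 h (a higher number here means a weaker inhibitor, a lower number a stronger inhibitor), are:
- compound 1 `COc1ccc(/C=C/C(=O)c2ccc(OC)c3c2OC(C)(C)C=C3)c(F)c1` gives 7560 nM
- compound 2 `COc1ccc(C(=O)/C=C/c2ccc(Br)cc2)c2c1C=CC(C)(C)O2` gives > 10000 nM (a limit, not a number)
- compound 3 `COc1ccc(C(=O)/C=C/c2ccc(N(C)C)cc2)c2c1C=CC(C)(C)O2` gives 730 nM

Compound 3 stands lowest in this assay and is the strongest inhibitor of the three. Compound 4 `COc1ccc(/C=C/C(=O)c2ccc(OC)c3c2OC(C)(C)C=C3)cn1` has not yet been measured. Its difference from compound 3 is 6-methoxypyridin-3-yl in place of 4-(dimethylamino)phenyl on a double-bonded chain carbon bound to a double-bonded chain carbon and puts 6-methoxypyridin-3-yl in place of 4-(dimethylamino)phenyl on a double-bonded chain carbon bound to a double-bonded chain carbon.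

Within the data shown here, two measured steps bear on this change, both large and beyond the scatter, and both end at compound 3: a 10-fold lower number from compound 1 to compound 3 (1.02 log units; beyond the scatter) and an at least 13-fold lower number from compound 2 to compound 3 (1.13 log units; beyond the scatter) were seen. Compound 4 gives up the 4-(dimethylamino)phenyl and keeps a methoxy on its ring, as compound 1 at 7560 nM does in its 2-fluoro-4-methoxyphenyl. A large move to a higher number in this assay is therefore expected, and the expected size is a 6.8-fold higher number from compound 3 to compound 4 (0.84 log units; beyond the scatter) beyond the scatter. For compound 4 the estimated value is 5000 nM with an expected range from 1500 nM to 15000 nM in this measurement.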

Compound 4, half-maximal inhibitory concentration: > 10000 nM
Compound 4: a limit, no number; the forecaster's own chance of this, stated with the estimate: 25%; middle value at least 2.0-fold (0.30 log units) away from the limit.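

In this assay compound 4 gives > 10000 nM, which is a limit of the assay and not a number. The step to 6-methoxypyridin-3-yl, an at least 13-fold higher number from compound 3 to compound 4 (1.13 log units; beyond the scatter), shows that a ring with a hetero atom in this place does not keep what the 4-(dimethylamino)phenyl gives, so all three other groups shown here stand well apart from compound 3. The step of an at least 1.3-fold higher number from compound 1 to compound 4 (0.12 log units; that floor lies within the scatter) sets no order between the two methoxy-bearing rings, and the step between compound 2 and compound 4 cannot be read because both values are limits: the limit of > 10000 nM in this assay, at which 2 of the 4 values shown sit.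

On these data alone, how far compound 4 lies beyond its limit stays open. As far as these compounds go, only compound 3 carries the dimethylamino, so it also stays open whether a primary amine, a pyrrolidine or a dimethylamino on a pyridine ring would hold its value.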